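Swapping Methyl for Cyano on a Shared Core

The source may report more compounds than this note shows. Statements on the series, on what has been measured and on what is new or still open speak of the compounds shown alone.

Compound 1, `Cc1cccc(N2CCCC(=O)N2)c1`: 3400 nM
Compound 2, `CCc1ccccc1N1CCCC(=O)N1`: 39000 nM

Both compounds were tested in an assay on isolated protein for inhibition of Polyunsaturated fatty acid 5-lipoxygenase (Homo sapiens); on this read-out higher numbers stand for weaker inhibition and lower numbers for stronger inhibition. Compound 1 gives 3400 nM, the lowest of the two numbers. Compound 2 gives 39000 nM, and the gap between these two values lies beyond the usual scatter, so compound 1 is the stronger inhibitor of the pair.

Compound 3, `N#Cc1cccc(N2CCCC(=O)N2)c1`, has not yet been measured. It differs from compound 1 in one place: cyano in place of methyl on an aromatic carbon. Among the compounds with values here, no measured pair shows this exchange, so the expectation rests on compound 1 alone. A small step is expected, with no clear direction, most likely within the scatter or only slightly beyond it. The expected step is a 1.5-fold higher number from compound 1 to compound 3 (0.17 log units; within the scatter). For compound 3 the estimated value in this assay is 5000 nM, with a range from 1500 nM to 17000 nM.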

Compound 3, half-maximal inhibitory concentration: 9300 nM
The estimate for compound 3 lay 1.9-fold (0.27 log units) below the measured number; measured number inside the range.
By their numbers in this assay, from the lowest: compound 1; then compound 3; then compound 2.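

In this assay, within the data shown here, the exchange of methyl for cyano gives a 2.7-fold higher number from compound 1 to compound 3 (0.44 log units; beyond the scatter) and so offers the first direct reading at this position: what sits on this aromatic carbon changes the number, though only modestly. The entering cyano brings one more heavy atom and a hydrogen-bond acceptor, and compound 3 with 9300 nM remains an inhibitor with a defined value, so this change weakens inhibition without abolishing it. No measurement shown explains why the number rises.

From the compounds shown here alone, a single exchange cannot show a trend, so it stays open whether a chlorine, a methoxy group or an amine on this carbon would give a lower or a higher number. Going by these compounds, it is also open whether cyano in place of methyl would have a similar effect elsewhere on the ring.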